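Thiophen-2-yl for 4-methylphenyl on the sulfonyl sulfur

The source may report more compounds than this note shows. Statements on the series, on what has been measured and on what is new or still open speak of the compounds shown alone.

In a functional assay on MDA-MB-231 cells (Homo sapiens) for inhibition, read by sulforhodamine B assay, with a stated time of 74 h (on this read-out lower numbers stand for stronger inhibition and higher numbers for weaker inhibition), compound 2 (`Cc1ccc(S(=O)(=O)N2C(=O)C(C)OC23C=CC(=O)C=C3)cc1`) reads 1100 nM and is the higher of two numbers, against compound 1 (`Cc1ccc(S(=O)(=O)N2C(=O)COC23C=CC(=O)C=C3)cc1`) at 70 nM. Within the data shown here, the single measured step of a 16-fold higher number from compound 1 to compound 2 (1.20 log units; beyond the scatter) is large, but it is methyl in place of hydrogen on a saturated ring carbon and leaves the sulfonyl substituent unchanged. Compound 3 (`CC1OC2(C=CC(=O)C=C2)N(S(=O)(=O)c2cccs2)C1=O`) has thiophen-2-yl in place of 4-methylphenyl on a sulfonyl sulfur. Among the measured compounds shown here, no measured step covers that place, so in this assay the expected step of a 1.4-fold lower number from compound 2 to compound 3 (0.14 log units; within the scatter) stays within the scatter. Compound 3 is expected at 800 nM (300 nM to 3000 nM).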

Compound 3, half-maximal inhibitory concentration: > 10000 nM
Compound 3 was reported as a limit; the forecaster's own chance of this, stated with the estimate: 3%; middle value at least 12-fold (1.09 log units) from the limit.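

Thiophen-2-yl in place of 4-methylphenyl on a sulfonyl sulfur gives, in this assay, an at least 9.0-fold higher number from compound 2 to compound 3 (0.95 log units; beyond the scatter). The sulfonyl substituent, unchanged in the earlier step, is therefore a second place where one change moves the read-out beyond the scatter. The reading for compound 3 is a limit and not a number: the limit of > 10000 nM in this assay, at which 1 of the 3 values shown sits.

Open, as far as these compounds go, is whether this change has the same effect with hydrogen on the saturated ring carbon, as in compound 1. Also open, from the compounds shown here alone, is where a plain phenyl or a butyl chain on the sulfonyl sulfur would read.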